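A Fluorine Removed From a Methyl Ester

The source may hold more compounds than are shown below. What is called first, only, known or untested is meant among the compounds shown, and "the series" means these compounds.

The compounds here are small aromatic acids and esters. Compound 1 `O=C(O)c1c(O)c(F)c(F)c(F)c1F` and compound 2 `O=C(O)c1cc(F)c(F)c(F)c1O` are acids; compound 3 `COC(=O)c1c(O)c(F)c(F)c(F)c1F` and compound 4 `COC(=O)c1cc(F)c(F)c(F)c1O` are the matching methyl esters. They are tested in a functional assay on the whole organism for inhibition, with Rattus norvegicus as the target, read by paw edema, with stated times of 30 min and 3 h, at a dose of 50 mg/kg by the intraperitoneal route; on this read-out higher numbers stand for more inhibition at the one dose given (going by the name of the read-out) and lower numbers for less inhibition. In this assay compound 1 gives 64% and compound 2 gives 46.7%; no result reported (2 entries), and the record of compound 2 is mixed, with the several entries of compound 2 in this assay, 46.7%; no result reported (2 entries). Compound 3 stands without a number at all: in this assay compound 3 gives no result reported.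

The step to compound 4 is a single change, (hydrogen in place of fluoro on an aromatic carbon). For the measured compounds named here, no measured step shows what such a change does in this assay, so any expectation rests only on the acids. Compound 1 at 64% and compound 2 at 46.7%; no result reported (2 entries) differ by more than the usual scatter, which suggests that a fluorine lost from this core tends to lower the inhibition, though only these two acids speak for it. For compound 4 the change in this assay is expected to be downward by a modest amount, from whatever compound 3 would have shown, but the size is uncertain with no number for compound 3. Compound 4 is expected to give about 42%, within a range of 18% to 66%.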

Compound 4, a percentage reported as inhibition, in the whole organism at one dose (the size of the read-out at that dose, not a potency): 40.3%
Estimate against measurement, compound 4: 1.7 percentage points above; the measured number falls inside the stated range.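

Compound 3 has no single number in this assay, while compound 4 gives 40.3%, so no step can be read between these two methyl esters. The compounds shown leave open what hydrogen in place of fluoro does to the ester, and how firmly the acids can guide that question, given this mixed record: the several entries of compound 2 in this assay, 46.7%; no result reported (2 entries)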